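Fluorine placement on the benzyl group of the shared core

The source may report more compounds than this note shows. Statements on the series, on what has been measured and on what is new or still open speak of the compounds shown alone.

Measured in an assay on Sf21 cells for inhibition of high affinity nerve growth factor receptor (Homo sapiens), read by HTRF, with a stated time of 30 min, in the presence of a further agent that is not named here; a lower number here means a stronger inhibitor, a higher number a weaker inhibitor:
compound 1 `Cc1cccc(CN2Cc3c(NC(=O)c4ccccc4)n[nH]c3C2(C)C)c1`: 1100 nM
compound 2 `CC1(C)c2[nH]nc(NC(=O)c3ccccc3)c2CN1Cc1cccc(C#N)c1`: 980 nM
compound 3 `CC1(C)c2[nH]nc(NC(=O)c3ccccc3)c2CN1Cc1cccc(F)c1F`: 200 nM

Compound 3 stands lowest of the three numbers; its nearest neighbour is compound 2, reached by a 4.9-fold lower number from compound 2 to compound 3 (0.69 log units; beyond the scatter), and its furthest is compound 1, reached by a 5.5-fold lower number from compound 1 to compound 3 (0.74 log units; beyond the scatter). Both steps are modest and beyond the scatter, so compound 3 can be called the strongest inhibitor of the three. Compound 1 and compound 2 lie within the scatter of each other, a 1.1-fold lower number from compound 1 to compound 2 (0.05 log units; within the scatter).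

The next step keeps the core and the atom count and moves one fluorine: 2,4-difluorophenyl in place of 2,3-difluorophenyl on a saturated chain carbon bound to an amine nitrogen in a ring, giving compound 4 `CC1(C)c2[nH]nc(NC(=O)c3ccccc3)c2CN1Cc1ccc(F)cc1F`. Within the data shown here, no measured step bears directly on this change; the two steps beyond the scatter each exchange the whole substitution pattern of the benzyl ring, not the position of a single fluorine, and they show only that such exchanges can move the number modestly. With nothing pointing in either direction, the expected step is a 1.3-fold higher number from compound 3 to compound 4 (0.10 log units; within the scatter), within the scatter. Compound 4 is therefore estimated at 250 nM, with a range from 90 nM to 700 nM.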

Compound 4, half-maximal inhibitory concentration: 2320 nM
For compound 4 the middle estimate is 9.3-fold (0.97 log units) below the measured one, and the stated range ends below it.
By their numbers in this assay, from the lowest: compound 3; then compounds 2 and 1 (each within the scatter of the next); then compound 4.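

In this assay, moving one fluorine while keeping the same atoms gives a 12-fold higher number from compound 3 to compound 4 (1.06 log units; beyond the scatter), a larger step than any earlier exchange of the whole benzyl substitution pattern, so the arrangement of the two fluorines on this benzyl group matters and not only their presence. The 2,4-difluorophenyl group also makes compound 4 the weakest inhibitor of the four, with a 2.4-fold higher number from compound 2 to compound 4 (0.37 log units; beyond the scatter) and a 2.1-fold higher number from compound 1 to compound 4 (0.32 log units; beyond the scatter), so the gain seen with compound 3 does not extend to this other difluorophenyl group. No measurement available here accounts for the difference between the two difluorobenzyl groups.

Still open, from the compounds shown here alone, is how much of the number of compound 3 depends on each fluorine, as a benzyl group with a single fluorine would show. Going by these compounds, it is also open whether a chlorine or a methoxy group could stand in place of either fluorine.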